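The source may report more compounds than this note shows. Statements on the series, on what has been measured and on what is new or still open speak of the compounds shown alone.

Measured in a functional assay on SK-MEL-28 cells (Homo sapiens) for cytotoxicity, read by CCK-8 assay, with a stated time of 24 h; a lower number here means a stronger inhibitor, a higher number a weaker inhibitor:
- Compound 1 `COc1ccccc1Oc1c(N)nc(-c2cccc(Cl)c2)nc1Cl`: 19400 nM
- Compound 2 `COc1ccccc1Oc1c(N)nc(-c2ccccc2)nc1OCCO`: > 80000 nM
- Compound 3 `COc1ccccc1Oc1c(N)nc(-c2cccc(F)c2)nc1OCCO`: 3210 nM

The entry for compound 2, > 80000 nM, is a limit of the assay and not a number. Among the two true numbers in this assay, compound 3 has the lower, at 3210 nM. Its nearest neighbour is compound 1 at 19400 nM, a gap beyond the scatter.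

Compound 4 `COc1ccccc1Oc1c(N)nc(-c2cccc(Cl)c2)nc1OCCO` has not yet been measured. It differs from compound 3 by one exchange: chloro in place of fluoro on an aromatic carbon. In words, this is chloro in place of fluoro on an aromatic carbon, at the same place on the ring, so 3-fluorophenyl becomes 3-chlorophenyl.

Among the compounds with values here, only one measured step touches this position: an at least 24-fold lower number from compound 2 to compound 3 (1.39 log units; beyond the scatter), a large change that came with fluoro in place of hydrogen. That step shows that this position can matter in this assay. However, it compares fluoro with hydrogen, not chloro with fluoro, so it gives neither a size nor a direction for the present exchange.

The expectation is therefore of no step beyond the scatter, and the estimate means a 1.1-fold higher number from compound 3 to compound 4 (0.04 log units; within the scatter). For compound 4 the estimated value is 3500 nM, with an expected range from 1200 nM to 12000 nM.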

Compound 4, half-maximal inhibitory concentration: 4170 nM
Beside the measured number, compound 4's estimate is 1.2-fold (0.08 log units) below it; low and high end bracket the measured number.
By their numbers in this assay, from the lowest: compounds 3 and 4 (each within the scatter of the next); then compound 1. At a limit, above all of these: compound 2.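

In this assay, the exchange of fluoro for chloro on the aromatic carbon stays within the scatter, a 1.3-fold higher number from compound 3 to compound 4 (0.11 log units; within the scatter), so this read-out does not separate 3-fluorophenyl from 3-chlorophenyl on the shared core. Chloro in place of hydrogen also gives a large step, an at least 19-fold lower number from compound 2 to compound 4 (1.28 log units; beyond the scatter), which shows that the earlier drop seen with fluoro is not confined to that one halogen, and with 3-chlorophenyl held fixed, the other place on the core also counts, a 4.7-fold lower number from compound 1 to compound 4 (0.67 log units; beyond the scatter), with 2-hydroxyethoxy in place of chloro. The entry for compound 2, which anchors both hydrogen comparisons, is a limit of the assay and not a number: the limit of > 80000 nM in this assay, at which 1 of the 4 values shown sits.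

The compounds shown leave open whether bromo, methyl, methoxy, trifluoromethyl or a nitrile at this same place would stay level with fluoro and chloro or would break away from them. They also leave open how far the 2-hydroxyethoxy chain can be changed, for instance to a longer chain, an amine or a carboxylic acid, while 3-fluorophenyl or 3-chlorophenyl is kept.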